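Replacing a chlorobenzyl group on the shared core with fluorobenzyl

The compounds below may be only part of what the source reports. "The series", "measured", "known", "first", "only" and "open" are said of these compounds alone.

Compound 1 `CCCSc1nc(N/N=C(\C)c2ccc(O)cc2)c2nnn(Cc3ccccc3)c2n1`: 32500 nM
Compound 2 `CCCSc1nc(N/N=C(\C)c2ccccc2O)c2nnn(Cc3ccccc3Cl)c2n1`: > 64000 nM
Compound 3 `C#CCSc1nc(N/N=C/c2cc(OC)c(OC)c(OC)c2)c2nnn(Cc3ccccc3)c2n1`: 6540 nM

In a functional assay on ECa-109 cells (Homo sapiens) for antiproliferative activity, read by MTT assay, with a stated time of 72 h (on this read-out lower numbers stand for stronger inhibition and higher numbers for weaker inhibition), compound 2 gives only a limit, > 64000 nM, and no number. That puts compound 2 at the lowest end of the three values shown, alongside (the limit of > 64000 nM in this assay, at which 1 of the 3 values shown sits). Compound 1, with an unsubstituted benzyl group on the core and a different hydrazone part, gives 32500 nM in this assay, and compound 3, which differs from both in several places at once, gives 6540 nM; no single-change step connects any of these three compounds, so their values are simply shown side by side.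

Compound 4 `CCCSc1nc(N/N=C(\C)c2ccccc2O)c2nnn(Cc3ccc(F)cc3)c2n1` is not yet measured. It differs from compound 2 in one place: 4-fluorophenyl in place of 2-chlorophenyl on a saturated chain carbon bound to an aromatic nitrogen. Within the data shown here, no measured step of this kind is available among the three compounds, so there is no direct guide to its size or direction. The expected step from compound 2 to compound 4, an at least 1.4-fold lower number from compound 2 to compound 4 (0.15 log units; that floor lies within the scatter), is therefore set as none beyond the usual scatter, with the understanding that compound 2 itself is known only as a limit. On that basis compound 4 is expected to give about 45000 nM in this assay, with a range from 15000 nM to 130000 nM, and it may well return only a limit again.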

Compound 4, half-maximal inhibitory concentration: 21900 nM
The estimate for compound 4 lay 2.1-fold (0.31 log units) above the measured number; measured number inside the range.
By their numbers in this assay, from the lowest: compound 3; then compounds 4 and 1 (each within the scatter of the next). At a limit, above all of these: compound 2.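

In this assay, among these compounds, exchanging 2-chlorobenzyl for 4-fluorobenzyl on the shared core gives the first single-change step at this position, an at least 2.9-fold lower number from compound 2 to compound 4 (0.46 log units; beyond the scatter). With the rest of the molecule held constant, the group on a saturated chain carbon bound to an aromatic nitrogen therefore affects the read-out by more than the usual scatter, and compound 4 gives a measurable 21900 nM in this assay. The size of the step is only a floor, because compound 2 is known only as a limit, so the true gap could be larger: the limit of > 64000 nM in this assay, at which 1 of the 4 values shown sits.

Going by these compounds, the step changes both the halogen and its place on the ring, so it cannot show which of the two matters; 2-fluorobenzyl and 4-chlorobenzyl would each separate these two changes, and how either would read remains open. Also open, on these data alone, is whether the same exchange would have a similar effect alongside a different hydrazone part, or whether a benzyl group carrying a methoxy or a nitrile in place of the halogen would give a lower number still.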